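A few compounds are considered here, and "the series" means these few. Any claim that something is new, unique, unknown or untested is made for them only; others in the source may bear on it.

Measured so far in a functional assay on MCF7 cells (Homo sapiens) for antiproliferative activity, read by MTT assay, with a stated time of 48 h; on this read-out higher numbers stand for weaker inhibition and lower numbers for stronger inhibition:
- compound 1 `COc1ccc(-n2cc(COc3ccc(/C=C/C(C)=O)cc3OC)nn2)cc1`: 33700 nM
- compound 2 `COc1cc(/C=C/C(C)=O)ccc1OCc1cn(-c2ccc(C)cc2)nn1`: > 100000 nM (a limit of the assay, not a number)
- compound 3 `COc1cc(/C=C/C(C)=O)ccc1OCc1cn(-c2ccc(C=O)cc2)nn1`: 86400 nM

Of the two true numbers, the higher belongs to compound 3, at 86400 nM. The lower belongs to compound 1, at 33700 nM.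

The next compound is compound 4 `COc1cc(/C=C/C(C)=O)ccc1OCc1cn(-c2ccccc2O)nn1`, which has 2-hydroxyphenyl in place of 4-formylphenyl on an aromatic nitrogen.

For the measured compounds named here, three measured steps bear on this only indirectly, since each swaps one small group on an aromatic carbon and none introduces a 2-hydroxyphenyl. Changing methoxy to formyl gave a 2.6-fold higher number from compound 1 to compound 3 (0.41 log units; beyond the scatter), and changing methoxy to methyl gave an at least 2.9-fold higher number from compound 1 to compound 2 (0.47 log units; beyond the scatter). Changing methyl to formyl gave an at least 1.1-fold lower number from compound 2 to compound 3 (0.06 log units; that floor lies within the scatter). These steps show modest changes among weak compounds, so only a small change is expected, leaning towards a lower number and probably not beyond the scatter. The estimated step is a 1.4-fold lower number from compound 3 to compound 4 (0.16 log units; within the scatter). The estimate for compound 4 is 60000 nM, with an expected range from 25000 nM to 140000 nM.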

Compound 4, half-maximal inhibitory concentration: > 100000 nM
Compound 4 gave a limit, no number (the forecaster's own chance of this, stated with the estimate: 30%); middle value at least 1.6-fold (0.22 log units) from the limit.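

In this assay compound 4 gives > 100000 nM, a limit of the assay and not a number. Placing 2-hydroxyphenyl, the first group here with a hydrogen-bond donor, on the aromatic nitrogen shows no visible gain over 4-formylphenyl, with an at least 1.1-fold higher number from compound 3 to compound 4 (0.06 log units; that floor lies within the scatter), and it falls behind 4-methoxyphenyl, with an at least 2.9-fold higher number from compound 1 to compound 4 (0.47 log units; beyond the scatter). The step between compound 2 and compound 4 cannot be read, since both compounds sit at the same limit: the limit of > 100000 nM in this assay, at which 2 of the 4 values shown sit.

This change alters both the group and its place on the phenyl ring, so the compounds shown cannot separate the two effects. As far as these compounds go, how an amine or a carboxylic acid on that phenyl ring would compare with the methoxy group of compound 1 also stays open.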